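The source may hold more compounds than are shown below. What is called first, only, known or untested is meant among the compounds shown, and "the series" means these compounds.

In a functional assay on the whole organism for inhibition, with Rattus norvegicus as the target, read by cytopathic effect and paw edema, at a dose of 100 mg/kg by the oral route (on this read-out higher numbers stand for more inhibition at the one dose given (going by the name of the read-out) and lower numbers for less inhibition), compound 1 `COc1cccc(NC(=O)c2c(O)c3cccnc3n(-c3ccccc3)c2=O)c1` gives 20.7%. Compound 2 `O=C(NCc1cccnc1)c1c(O)c2cccnc2n(-c2ccccc2)c1=O` gives 14.7% in this assay, so a number 6 percentage points lower from compound 1 to compound 2 (within the scatter) and the two numbers sit within the scatter of one another. Compound 3 `O=C(Nc1ccc(Cl)nc1)c1c(O)c2cccnc2n(-c2ccccc2)c1=O` carries the change (6-chloropyridin-3-yl in place of 3-methoxyphenyl on an amide-type nitrogen). Among the compounds with values here, the only measured step, a number 6 percentage points lower from compound 1 to compound 2 (within the scatter), also exchanges the group on the amide-type nitrogen and stays within the scatter, so the step to compound 3 is expected to stay within the scatter too, with no direction to it. Compound 3 is therefore estimated at 18% in this assay, within 5% to 32%. The expected step is a number 2.7 percentage points lower from compound 1 to compound 3 (within the scatter).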

Compound 3, a percentage reported as inhibition, in the whole organism at one dose (the size of the read-out at that dose, not a potency): -4%
The estimate for compound 3 lay 22 percentage points above the measured number, and the stated range ends above it.
By their numbers in this assay, from the lowest: compound 3; then compounds 2 and 1 (each within the scatter of the next).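

In this assay, the group on the amide-type nitrogen can matter: (a number 24.7 percentage points lower from compound 1 to compound 3 (beyond the scatter)) and (a number 18.7 percentage points lower from compound 2 to compound 3 (beyond the scatter)) both lie beyond the scatter with 6-chloropyridin-3-yl entering, which the earlier step did not show. No measured evidence bears on the origin of these drops.

6-chloropyridin-3-yl differs from 3-methoxyphenyl in both the ring nitrogen and the chlorine, and the compounds shown do not separate the two. Also open, on these data alone, is how pyridin-3-yl without the chlorine, or a phenyl ring carrying a carboxylic acid, would read on this nitrogen.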